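Chlorine to iodine on a barely toxic series

The compounds below may be only part of what the source reports. "The series", "measured", "known", "first", "only" and "open" are said of these compounds alone.

Values in an ADME assay on BJ cells (Homo sapiens) for cytotoxicity, with a stated time of 72 h (on this read-out higher numbers stand for an effect only at larger amounts of compound and lower numbers for an effect already at smaller amounts), so far:
Compound 1 `CCc1ccc(-c2nc3c(c(C)nn3-c3ccccc3)c(-c3ccccc3O)c2C#N)cc1` gives > 20000 nM (a limit)
Compound 2 `Cc1nn(-c2ccccc2)c2nc(-c3ccc(C(C)C)cc3)c(C#N)c(-c3ccccc3O)c12` gives 22600 nM (a number)
Compound 3 `Cc1nn(-c2ccccc2)c2nc(-c3ccc(Cl)cc3)c(C#N)c(-c3ccccc3O)c12` gives > 20000 nM (a limit)

Compound 3 stands at > 20000 nM and this is a limit, not a number. Compound 4 `Cc1nn(-c2ccccc2)c2nc(-c3ccc(I)cc3)c(C#N)c(-c3ccccc3O)c12` differs from it by one swap, (iodo in place of chloro on an aromatic carbon), which is iodo in place of chloro on an aromatic carbon, so that 4-chlorophenyl becomes 4-iodophenyl.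

Among the measured compounds shown here, no measured step involves iodine. The nearest evidence comes from other swaps of the group on that same aromatic carbon, namely a step that the two limits leave unreadable from compound 1 to compound 3 and a step that the limit leaves unreadable from compound 2 to compound 3, and neither has a size that can be read. What the series does show is the limit of > 20000 nM in this assay, at which 2 of the 3 values shown sit. For the measured compounds named here, compound 2 gives the only true number, 22600 nM.

With no readable step to build on, no change beyond the usual scatter is expected in this assay, and no direction can be argued. The estimated change is a number no higher from compound 3 to compound 4 (the limit leaves the size open), and it should be read as no real shift. In this assay compound 4 is expected at 20000 nM within a range of 9000 nM to 40000 nM. Once measured, compound 4 may well yield only a limit.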

Compound 4, half-maximal effective concentration: 19000 nM
Compound 4: the middle estimate sits 1.1-fold (0.02 log units) above what was measured; low and high end bracket the measured number.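

Compound 4 gives the series its second true number in this assay, so iodo on this aromatic carbon can be compared directly with another group: putting it in place of isopropyl gives a 1.2-fold lower number from compound 2 to compound 4 (0.08 log units; within the scatter). The two steps that start from a limit give only floors, an at least 1.0-fold lower number from compound 3 to compound 4 (0.02 log units; that floor lies within the scatter) and an at least 1.0-fold lower number from compound 1 to compound 4 (0.02 log units; that floor lies within the scatter), and both floors lie within the scatter, so neither swap can be shown to change anything. Ethyl, isopropyl, chloro and iodo at this place have not been separated from one another, and the values still gather at one mark: the limit of > 20000 nM in this assay, at which 2 of the 4 values shown sit.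

The earlier steps among compound 1, compound 2 and compound 3 cannot be read, and the compounds shown leave open whether any group on this carbon would bring an effect at clearly smaller amounts. From the compounds shown here alone, an amine or a carboxylic acid at this place is not among them, so it remains unknown whether this flat picture holds beyond these four groups, which are all either halogens or short hydrocarbon chains.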